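From tert-butyl to phenyl on an aromatic carbon

This account rests on a few compounds, and the source may have more. Where it says the series, first, only, none or still open, it means among the compounds named here.

For the measured compounds named here, in a physicochemical assay for lipophilicity, measured as octanol-water partition (a higher number here means a more lipophilic compound, a lower number a more polar compound), only two compounds have values so far. Compound 1 (`CC(C)(C)c1ccc(/C=C/C(=O)N[C@@H]2O[C@H](CO)[C@@H](O)[C@H](O)[C@H]2O)cc1`) gives 0.496 and stands highest of the pair. Compound 2 (`CC[C@H](CC(=O)N[C@@H]1O[C@H](CO)[C@@H](O)[C@H](O)[C@H]1O)c1ccc(C)c(C)c1`) gives 0.01 as its reading, and the gap between the two lies beyond the usual scatter of the measurement. These two compounds differ in more than one place, so that gap cannot be tied to any single change.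

The next compound, compound 3 (`O=C(/C=C/c1ccc(-c2ccccc2)cc1)N[C@@H]1O[C@H](CO)[C@@H](O)[C@H](O)[C@H]1O`), keeps the core of compound 1 and changes one group: phenyl in place of tert-butyl on an aromatic carbon, para to a large group (phenyl in place of tert-butyl on an aromatic carbon). Going by the values given here, no measured pair isolates such a change, so the expectation rests on the structures alone. Both groups are carbon only and carry no net charge, though phenyl brings a ring where tert-butyl had none. Taking compound 1 at 0.496 as the anchor, no step beyond the scatter is expected in this assay in either direction. The estimated step is a number 0.00 log units higher from compound 1 to compound 3 (within the scatter) as a working figure. Compound 3 is expected at 0.5 with an estimated range from 0.1 to 0.9 on this scale.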

Compound 3, partition coefficient: 0.851
For compound 3 the middle estimate is 0.35 log units below the measured one; low and high end bracket the measured number.
By their numbers in this assay, from the lowest: compound 2; then compound 1; then compound 3.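

In this assay, for the compounds shown here, phenyl in place of tert-butyl on an aromatic carbon, para to a large group, gives a number 0.36 log units higher from compound 1 to compound 3 (beyond the scatter) and is the first step here that can be tied to a single change. The earlier gap could not be assigned to any one place, whereas this pair shows that the reading responds to a change at this position even when both groups are carbon only, with no hydrogen-bond donors, no hydrogen-bond acceptors and no net charge. The swap replaces 4 heavy atoms and no ring with 6 heavy atoms and one six-membered aromatic ring of carbon only, but nothing measured here separates these differences or accounts for the step.

From the compounds shown here alone, with a single swap at this position, it remains open whether a saturated ring such as cyclohexyl would read closer to phenyl or to tert-butyl. Going by these compounds, how far the reading would move with an amine or a carboxylic acid on this aromatic carbon is also open, as is whether the same swap would give a similar step on a different core.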